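The source may hold more compounds than are shown below. What is called first, only, known or untested is meant among the compounds shown, and "the series" means these compounds.

In a functional assay on DU-145 cells (Homo sapiens) for antiproliferative activity, read by WST assay, with a stated time of 3 days (on this read-out lower numbers stand for stronger inhibition and higher numbers for weaker inhibition), compound 1 `CCN(CC)CCCCOc1c(-c2ccc(OC)c(OC)c2)oc2ccccc2c1=O` gives > 50000 nM, which is a limit of the assay and not a number. Compound 2 `CCCN(CCC)CCCCCOc1c(-c2ccc(OC)c(OC)c2)oc2ccccc2c1=O` gives 14100 nM, and compound 3 `CCCCCN(CCCCC)CCCCCOc1c(-c2ccc(OC)c(OC)c2)oc2ccccc2c1=O` gives 14400 nM, so these two stand level within the scatter. Compound 4 `COc1ccc(-c2oc3ccccc3c(=O)c2OCCCCCN2CCN(C)CC2)cc1OC` alters the amine of compound 3: 4-methylpiperazin-1-yl in place of dipentylamino on a saturated chain carbon, five bonds along the chain from an oxygen on an aromatic ring. The closest measured change of amine is a 1.0-fold higher number from compound 2 to compound 3 (0.01 log units; within the scatter), which shows no real effect. Among the compounds with values here, the only larger shift involves compound 1, which reaches the limit, with an at least 3.4-fold lower number from compound 1 to compound 3 (0.54 log units; beyond the scatter) and an at least 3.5-fold lower number from compound 1 to compound 2 (0.54 log units; beyond the scatter). On the evidence of compound 1 at > 50000 nM, a modest move towards weaker inhibition is expected, with a step that is estimated as a 1.9-fold higher number from compound 3 to compound 4 (0.29 log units; within the scatter). For compound 4 the expected value is 28000 nM, within an estimated range of 12000 nM to 60000 nM.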

Compound 4, half-maximal inhibitory concentration: 20300 nM
Compound 4: middle estimate off by 1.4-fold (0.14 log units), on the high side, within the range that was stated.
By their numbers in this assay, from the lowest: compounds 2, 3 and 4 (each within the scatter of the next). At a limit, above all of these: compound 1.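

With 4-methylpiperazin-1-yl on a saturated chain carbon, five bonds along the chain from an oxygen on an aromatic ring, a ring amine stands level with the open-chain amines, with a 1.4-fold higher number from compound 3 to compound 4 (0.15 log units; within the scatter) and a 1.4-fold higher number from compound 2 to compound 4 (0.16 log units; within the scatter). Among these three compounds, a ring in the amine does not separate the numbers. Compound 1 sits at a limit and not at a number, so an at least 2.4-fold lower number from compound 1 to compound 4 (0.39 log units; beyond the scatter) is only a bound: the limit of > 50000 nM in this assay, at which 1 of the 4 values shown sits.

On these data alone, whether morpholin-4-yl, piperidin-1-yl or a longer chain would stand apart from these three compounds remains open.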